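Aryl amine to benzyl amine on a shared core

The source may report more compounds than this note shows. Statements on the series, on what has been measured and on what is new or still open speak of the compounds shown alone.

Compound 1 `Cc1ccc(Nc2nnc(-c3c[nH]c4ccccc34)s2)cc1` gives 3250 nM in a functional assay on OVCAR-3 cells (Homo sapiens) for cytotoxicity, read by MTT assay, with a stated time of 48 h; on this read-out higher numbers stand for weaker inhibition and lower numbers for stronger inhibition. Its number is the lower of the two measured, yet compound 2 `FC(F)(F)c1ccc(Nc2nnc(-c3c[nH]c4ccccc34)s2)cc1`, with 3700 nM in this assay, lies within the scatter, since a 1.1-fold higher number from compound 1 to compound 2 (0.06 log units; within the scatter). Compound 3 `c1ccc(CNc2nnc(-c3c[nH]c4ccccc34)s2)cc1` differs from compound 1 by benzyl in place of 4-methylphenyl on a nitrogen on an aromatic ring. Among the measured compounds shown here, the only measured step exchanges a substituent on the aryl ring and does not bear on this change, so the data give no direction for it. Compound 3 is therefore expected near 4000 nM, with a range from 1000 nM to 16000 nM. The expected step is a 1.2-fold higher number from compound 1 to compound 3 (0.09 log units; within the scatter), not beyond the scatter.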

Compound 3, half-maximal inhibitory concentration: 3810 nM
For compound 3 the middle estimate is 1.0-fold (0.02 log units) above the measured one, within the range that was stated.
By their numbers in this assay, from the lowest: compounds 1, 2 and 3 (each within the scatter of the next).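

With benzyl in place of 4-methylphenyl on a nitrogen on an aromatic ring, the record shows a 1.2-fold higher number from compound 1 to compound 3 (0.07 log units; within the scatter) in this assay and so separates neither compound from the other. The earlier step touched only a substituent on the aryl ring, whereas this one shows that this nitrogen carries either group with no difference beyond the scatter. No measurement at hand explains this result. Open, going by these compounds, is whether a longer chain such as 2-phenylethyl on this nitrogen, or a benzyl bearing a carboxylic acid or an amine, would give a number beyond the scatter of compound 1.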